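Triazole Aryl Variation in a Spirooxindole Antiproliferative Series

This account rests on a few compounds, and the source may have more. Where it says the series, first, only, none or still open, it means among the compounds named here.

Measured compounds:
compound 1, `Cc1ccccc1-n1nncc1CN1C(=O)C2(C(C#N)=C(N)Oc3c(N)cc4nc5ccccc5nc4c32)c2ccccc21`: 31700 nM
compound 2, `N#CC1=C(N)Oc2c(N)cc3nc4ccccc4nc3c2C12C(=O)N(Cc1cnnn1-c1cccc(C(F)(F)F)c1)c1ccccc12`: 5400 nM
compound 3, `Cc1cc(C)cc(-n2nncc2CN2C(=O)C3(C(C#N)=C(N)Oc4c(N)cc5nc6ccccc6nc5c43)c3ccccc32)c1`: 31200 nM

In a functional assay on A549 cells (Homo sapiens) for antiproliferative activity, read by MTT assay, with a stated time of 48 h (on this read-out lower numbers stand for stronger inhibition and higher numbers for weaker inhibition), compound 3 gives the second highest of the three numbers. Its nearest neighbour is compound 1, with a 1.0-fold lower number from compound 1 to compound 3 (0.01 log units; within the scatter), a difference within the scatter. Going by the values given here, the only change that moved the number beyond the scatter is a 5.8-fold higher number from compound 2 to compound 3 (0.76 log units; beyond the scatter).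

Compound 4, `N#CC1=C(N)Oc2c(N)cc3nc4ccccc4nc3c2C12C(=O)N(Cc1cnnn1-c1ccc([N+](=O)[O-])cc1[N+](=O)[O-])c1ccccc12`, is the next step from compound 3: 2,4-dinitrophenyl in place of 3,5-dimethylphenyl on an aromatic nitrogen. Among the compounds with values here, no measured pair carries a nitro-bearing aryl group, so the step is only loosely anchored. Within the data shown here, the one informative comparison, a 5.8-fold higher number from compound 2 to compound 3 (0.76 log units; beyond the scatter), shows that replacing the dimethylphenyl by a different meta-substituted aryl gave a lower number, and a modest step downward in this assay is expected for compound 4, of roughly a 2.8-fold lower number from compound 3 to compound 4 (0.45 log units; beyond the scatter). Compound 4 is therefore estimated at 11000 nM, with a range from 3500 nM to 35000 nM.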

Compound 4, half-maximal inhibitory concentration: > 50000 nM
Compound 4 was reported as a limit (the forecaster's own chance of this, stated with the estimate: 5%); middle value at least 4.5-fold (0.65 log units) away from the limit.
By their numbers in this assay, from the lowest: compound 2; then compounds 3 and 1 (each within the scatter of the next). At a limit, above all of these: compound 4.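

In this assay compound 4 stands at a limit, not a number: the limit of > 50000 nM in this assay, at which 1 of the 4 values shown sits. The 2,4-dinitrophenyl group on this aromatic nitrogen does not retain the level of the 3-(trifluoromethyl)phenyl group, with an at least 9.2-fold higher number from compound 2 to compound 4 (0.96 log units; beyond the scatter). The floors of an at least 1.6-fold higher number from compound 3 to compound 4 (0.20 log units; that floor lies within the scatter) and an at least 1.5-fold higher number from compound 1 to compound 4 (0.19 log units; that floor lies within the scatter) cannot settle those two gaps, so no order can be given for either pair.

Open, as far as these compounds go, is whether a phenyl carrying a single nitro group, or an amine or a carboxylic acid, would stay near compound 2 or fall to the limit.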